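A Chloro Removed Where Three Compounds Stay at the Limit

The source may report more compounds than this note shows. Statements on the series, on what has been measured and on what is new or still open speak of the compounds shown alone.

Compound 1 `ClCc1ccc(Cn2cnc3nc(Cl)nc(Cl)c32)cc1`: > 100000 nM
Compound 2 `ClCc1ccccc1Cn1cnc2ncnc(Cl)c21`: > 100000 nM
Compound 3 `ClCc1ccccc1Cn1cnc2nc(Cl)nc(Cl)c21`: > 100000 nM

The three measured compounds were tested in a functional assay on HT-29 cells (Homo sapiens) for cytotoxicity, read by sulforhodamine B assay, with a stated time of 48 h; on this read-out lower numbers stand for stronger inhibition of growth and higher numbers for weaker inhibition of growth. Each of the three values is a limit of that assay, not a number: the growth of the cells was not fully stopped within the range tested. For compound 1 the result is a limit. For compound 2 the result is a limit as well. For compound 3 the result is likewise a limit.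

Compound 3 and compound 2 differ in one place, (hydrogen in place of chloro on an aromatic carbon). The step that the two limits leave unreadable from compound 3 to compound 2 cannot be read, since both ends sit at a limit.

Compound 4 `ClCc1ccc(Cn2cnc3ncnc(Cl)c32)cc1` has not yet been measured. It differs from compound 1 by hydrogen in place of chloro on an aromatic carbon. The words describing the place of this change are the same, word for word, as for the change from compound 3 to compound 2, so it is the same change on a different core. How the core of compound 1 differs from the core of compound 3 is not broken down here.

Because every measured value sits at the same limit (the limit of > 100000 nM in this assay, at which 3 of the 3 values shown sit), compound 4 is expected to behave as its neighbours do. The step of a number no higher from compound 1 to compound 4 (the limit leaves the size open) is expected to be too small to read. Compound 4 is estimated at 100000 nM, with a range from 40000 nM to 300000 nM, most likely reported only as a limit.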

Compound 4, concentration for total growth inhibition: 3630 nM
For compound 4 the middle estimate is 28-fold (1.44 log units) above the measured one; measured number below the stated range.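

In this assay, hydrogen in place of chloro on an aromatic carbon, between two ring nitrogen atoms, gives an at least 27-fold lower number from compound 1 to compound 4 (1.44 log units; beyond the scatter) on the core of compound 1, so on this core the change takes a compound from a limit of the assay to a real measured number and stronger inhibition of growth. Compound 1 is only a limit, so the full size of this step stays open, and a single pair gives no reason for the result. The same change cannot be shown to carry over to the other core, and the step from compound 3 to compound 2 cannot be read because both of its ends give no number, only the limit: the limit of > 100000 nM in this assay, at which 3 of the 4 values shown sit.

The compounds shown leave open whether hydrogen is the only replacement that gives this result, or whether an amine or a methoxy group in the same place would give a measured number too. They also leave open what would happen on either core if the remaining chloro group, meta to the place of the change, gave way to an amine or a carboxylic acid.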